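This account rests on a few compounds, and the source may have more. Where it says the series, first, only, none or still open, it means among the compounds named here.

In a functional assay on HL-60 cells (Homo sapiens) for cytotoxicity, read by WST assay, with a stated time of 48 h (a lower number here means that less compound is needed, a higher number that more compound is needed for the effect), compound 3 `O=C1OC[C@H](Cc2ccccc2)[C@H]1Cc1cccc(O)c1` gives > 100000 nM, which is a limit of the assay and not a number. Compound 1 `O=C1OC[C@H](Cc2ccccc2)[C@H]1Cc1ccccc1` gives 77000 nM, and compound 2 `O=C1OC[C@H](Cc2ccccc2)[C@H]1Cc1ccccc1Cl` gives 37000 nM.

Compound 4 `COc1cccc(C[C@H]2C(=O)OC[C@@H]2Cc2ccccc2)c1` differs from compound 3 by methyl in place of hydrogen on an oxygen on an aromatic ring, that is, hydroxy to methoxy. Going by the values given here, no measured step makes this same change, so the evidence is indirect. The closest is the entry of the hydroxy itself, an at least 1.2-fold higher number from compound 1 to compound 3 (0.11 log units; that floor lies within the scatter), a floor that lies within the scatter. Chloro in place of hydrogen on an aromatic carbon gave a 2.1-fold lower number from compound 1 to compound 2 (0.32 log units; beyond the scatter), a modest step, and the two substituted compounds are separated by an at least 2.7-fold higher number from compound 2 to compound 3 (0.43 log units; beyond the scatter).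

Single changes on this aromatic ring have therefore been modest so far, and a step of modest size or none beyond the scatter is expected in this assay. The start at a limit leaves only a lower number as a direction that could be read, and compound 4 may also reach the limit. The expected change is an at least 1.4-fold lower number from compound 3 to compound 4 (0.15 log units; that floor lies within the scatter). Compound 4 is estimated at 70000 nM, with an expected range of 30000 nM to 150000 nM.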

Compound 4, half-maximal effective concentration: 66000 nM
Compound 4: the middle estimate sits 1.1-fold (0.03 log units) above what was measured, within the range that was stated.
By their numbers in this assay, from the lowest: compounds 2, 4 and 1 (each within the scatter of the next, the first and the last beyond it). At a limit, above all of these: compound 3.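

In this assay, the change from hydroxy to methoxy gives an at least 1.5-fold lower number from compound 3 to compound 4 (0.18 log units; that floor lies within the scatter), so the size of this step has only a floor, and that floor does not separate the two compounds. The value of compound 3 is a limit and not a number, and it is the only such value in the series shown: the limit of > 100000 nM in this assay, at which 1 of the 4 values shown sits. Against the unsubstituted ring, adding the methoxy gives a 1.2-fold lower number from compound 1 to compound 4 (0.07 log units; within the scatter), so the methoxy compound and the unsubstituted compound cannot be told apart in this assay, and the oxygen substituent with the methyl gives a measured number where the hydroxy gives only a limit.

Left open is whether an amine or a carboxylic acid on this aromatic ring would read like the methoxy or like the hydroxy, and whether a longer chain on the oxygen, such as ethoxy, would stay within the scatter of compound 4. Also open, from the compounds shown here alone, is whether chloro and methoxy together on one aromatic ring would go beyond the step seen for chloro alone, a 2.1-fold lower number from compound 1 to compound 2 (0.32 log units; beyond the scatter).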